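Aryl swap on the dihydroxyphenyl member of the series

The source may hold more compounds than are shown below. What is called first, only, known or untested is meant among the compounds shown, and "the series" means these compounds.

Measured in a functional assay on KBVIN cells (Homo sapiens) for antiproliferative activity, read by sulforhodamine B assay, with a stated time of 3 days; a higher number here means that more compound is needed for the effect, a lower number that less compound is needed
compound 1 `CCC1=C(O)c2c(oc(-c3ccc(C(C)C)cc3)cc2=O)C(CC)(CC)C1=O` gives 1.08 uM
compound 2 `CCC1=C(O)c2c(oc(-c3ccc(SC)cc3)cc2=O)C(CC)(CC)C1=O` gives 1.38 uM
compound 3 `CCC1=C(O)c2c(oc(-c3ccc(O)c(O)c3)cc2=O)C(CC)(CC)C1=O` gives 5.41 uM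

Compound 3 carries the highest number of the three. The steps up to it are a 5.0-fold higher number from compound 1 to compound 3 (0.70 log units; beyond the scatter) and a 3.9-fold higher number from compound 2 to compound 3 (0.59 log units; beyond the scatter) while a 1.3-fold higher number from compound 1 to compound 2 (0.11 log units; within the scatter) stays within the scatter. Compound 4 `CCC1=C(O)c2c(oc(-c3cc(C)ccc3C)cc2=O)C(CC)(CC)C1=O` has 2,5-dimethylphenyl in place of 3,4-dihydroxyphenyl next to the ring oxygen 2,5-dimethylphenyl in place of 3,4-dihydroxyphenyl on an aromatic carbon on the shared core. The two steps up to compound 3 bear on this change read in reverse, although neither compound 1 nor compound 2 carries this exact group. A modest move to a lower number in this assay is therefore expected, with the estimated step being a 3.4-fold lower number from compound 3 to compound 4 (0.53 log units; beyond the scatter) overall. Compound 4 is estimated at 1.6 uM with an expected range of 0.7 uM to 4 uM for the measurement.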

Compound 4, concentration for half-maximal effect: 3.41 uM
Compound 4: the middle estimate sits 2.1-fold (0.33 log units) below what was measured; low and high end bracket the measured number.
By their numbers in this assay, from the lowest: compounds 1 and 2 (each within the scatter of the next); then compounds 4 and 3 (each within the scatter of the next).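

In this assay the loss of both hydroxyl groups in favour of two methyl groups leaves the number within the scatter (a 1.6-fold lower number from compound 3 to compound 4 (0.20 log units; within the scatter)), so 2,5-dimethylphenyl does not clearly separate from 3,4-dihydroxyphenyl at this position. An aryl group without hydroxyl groups is therefore not enough to reach the lower numbers, since 2,5-dimethylphenyl still reads beyond the scatter against 4-(methylsulfanyl)phenyl (a 2.5-fold higher number from compound 2 to compound 4 (0.39 log units; beyond the scatter)) and 4-isopropylphenyl (a 3.2-fold higher number from compound 1 to compound 4 (0.50 log units; beyond the scatter)). No supporting data offer an explanation for these steps. Still open, as far as these compounds go, is how an aryl group carrying an amine or a carboxylic acid would read at this position.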